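Swapping iodo for methyl on a halogenated uracil nucleoside

The compounds below may be only part of what the source reports. "The series", "measured", "known", "first", "only" and "open" are said of these compounds alone.

Compound 1 `C=C1C(n2cc(Cl)c(=O)[nH]c2=O)O[C@H](CO)[C@@H]1O`: in a functional assay on L1210 cells (Mus musculus) for cytotoxicity (on this read-out higher numbers stand for weaker inhibition and lower numbers for stronger inhibition), compound 1 gives > 100 ug/mL, which is a limit of the assay.
Compound 2 `C=C1C(n2cc(Br)c(=O)[nH]c2=O)O[C@H](CO)[C@@H]1O`: in this assay compound 2 gives > 100 ug/mL, which is a limit of the assay.
Compound 3 `C=C1C(n2cc(I)c(=O)[nH]c2=O)O[C@H](CO)[C@@H]1O`: in this assay compound 3 gives > 100 ug/mL, which is a limit of the assay.

All three measured compounds share one core and differ only in the halogen on the aromatic carbon. Compound 3 therefore does not stand at a known number: its result is a limit, and the other two results shown are limits as well, so that (the limit of > 100 ug/mL in this assay, at which 3 of the 3 values shown sit). For the same reason the step that the two limits leave unreadable from compound 1 to compound 2, the step that the two limits leave unreadable from compound 1 to compound 3 and the step that the two limits leave unreadable from compound 2 to compound 3 cannot be sized; they show only that exchanging one halogen for another never brought any of these compounds inside the measurable range.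

Compound 4 `C=C1C(n2cc(C)c(=O)[nH]c2=O)O[C@H](CO)[C@@H]1O` is the next member of the series. The change from compound 3 is methyl in place of iodo on an aromatic carbon. Within the data shown here, no measured step here moves a halogen to a methyl, so the three unreadable halogen steps bear on it only loosely: they suggest that small changes at this position left the compounds outside the range, and nothing points the other way.

On that basis compound 4 is expected to come out near 100 ug/mL in this assay, most likely again as a limit, with a range from 30 ug/mL to 300 ug/mL. The step of a number no higher from compound 3 to compound 4 (the limit leaves the size open) is thus expected to be none beyond the scatter.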

Compound 4, half-maximal inhibitory concentration: 50 ug/mL
Estimate against measurement, compound 4: 2.0-fold (0.30 log units) above; measured number inside the range.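

Methyl in place of the halogen gives the series its first number inside the measurable range, as compound 4 reads 50 ug/mL in this assay. The halogen compounds stop at the assay's limit: the limit of > 100 ug/mL in this assay, at which 3 of the 4 values shown sit. The new steps are an at least 2.0-fold lower number from compound 3 to compound 4 (0.30 log units; that floor lies within the scatter), an at least 2.0-fold lower number from compound 2 to compound 4 (0.30 log units; that floor lies within the scatter) and an at least 2.0-fold lower number from compound 1 to compound 4 (0.30 log units; that floor lies within the scatter); each is only a floor, so the true difference could be barely more than ordinary assay noise or considerably larger. Even so, the position is now shown to tolerate a change that yields a readable cytotoxic effect on these cells, something that no exchange of one halogen for another had shown.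

On these data alone, the steps among the three halogen compounds still cannot be read, so how chloro, bromo and iodo rank against one another remains unknown, as does the true size of their gap to methyl. The compounds shown also leave open whether the readable value is particular to methyl or would persist with a longer chain such as ethyl, or with an amine on the same aromatic carbon.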